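This account rests on a few compounds, and the source may have more. Where it says the series, first, only, none or still open, it means among the compounds named here.

Measured so far:
- compound 1 `COc1ccc(C(=O)/C=C/c2cc(-c3cc(OC)c(OC)c(OC)c3)n[nH]2)cc1OC`: 8590 nM in a functional assay on SF-268 cells (Homo sapiens) for inhibition, read by sulforhodamine B assay, with a stated time of 48 h; a lower number here means that less compound is tolerated, a higher number that more compound is tolerated
- compound 2 `COc1ccc(C(=O)/C=C/c2cc(-c3cc(OC)c(OC)c(OC)c3)n[nH]2)cc1`: in this assay compound 2 gives only a limit, > 100000 nM

Among the compounds with values here, compound 1 stands as the sole numeric value in this assay; the other entry is a limit, as the limit of > 100000 nM in this assay, at which 1 of the 2 values shown sits, records. Within the data shown here, the one measured step, an at least 11-fold higher number from compound 1 to compound 2 (1.06 log units; beyond the scatter), came from hydrogen in place of methoxy on an aromatic carbon and was large. Compound 3 `COc1cc(C(=O)/C=C/c2cc(-c3cc(OC)c(OC)c(OC)c3)n[nH]2)cc(OC)c1OC` differs from compound 1 by methoxy in place of hydrogen on an aromatic carbon. This change runs the other way from the measured step, adding a methoxy rather than removing one, so the measured step bears on it only indirectly: loss of a methoxy cost tolerance heavily, which suggests that gaining one may lower the number somewhat, though a step within the scatter is also plausible. The estimated step of a 1.7-fold lower number from compound 1 to compound 3 (0.24 log units; within the scatter) is a modest lowering. Compound 3 is therefore expected to give 5000 nM, within a range from 1500 nM to 15000 nM.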

Compound 3, concentration lethal to 50% of the cells: 14200 nM
Estimate against measurement, compound 3: 2.8-fold (0.45 log units) below; the measured number falls inside the stated range.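

Methoxy in place of hydrogen, on the aromatic carbon ortho to a methoxy group, gives a 1.7-fold higher number from compound 1 to compound 3 (0.22 log units; within the scatter) in this assay, so at this position the added group leaves no readable mark on the number. The earlier step, an at least 11-fold higher number from compound 1 to compound 2 (1.06 log units; beyond the scatter), was large, so these two changes in methoxy count do not behave alike: one methoxy counted for much, while the further one did not show. The earlier step rests on a limit, not on a number: the limit of > 100000 nM in this assay, at which 1 of the 3 values shown sits.

The compounds shown leave open whether a different group at this position, such as a hydroxyl, an amine or a longer chain like ethoxy, would also stay within the scatter of compound 1. They also leave open whether removing a methoxy elsewhere on the shared core would count as heavily.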